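From an Aromatic to a Cyclohexyl Amide

The compounds below may be only part of what the source reports. "The series", "measured", "known", "first", "only" and "open" are said of these compounds alone.

In a functional assay on U-937 cells (Homo sapiens) for cytotoxicity, read by MTT assay, with a stated time of 24 h (a lower number here means a stronger inhibitor, a higher number a weaker inhibitor), compound 1 `Nc1nn(Cc2cn(-c3ccc(F)c(Cl)c3)nn2)c2nc(-c3ccccc3)cc(C(F)(F)F)c12` gives 99.1 ug/mL and compound 2 `Nc1nn(Cc2cn(-c3ccc([N+](=O)[O-])cc3)nn2)c2nc(-c3ccccc3)cc(C(F)(F)F)c12` gives 98.8 ug/mL. Compound 3 `Cc1ccc(NC(=O)Cn2cc(Cn3nc(N)c4c(C(F)(F)F)cc(-c5ccccc5)nc43)nn2)cc1` shares their core and gives 65.3 ug/mL, which places it within the scatter of both. The three compounds differ only in the group on an aromatic nitrogen, and the measured steps among them are small. They are a 1.0-fold lower number from compound 1 to compound 2 (0.00 log units; within the scatter), a 1.5-fold lower number from compound 1 to compound 3 (0.18 log units; within the scatter) and a 1.5-fold lower number from compound 2 to compound 3 (0.18 log units; within the scatter).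

Compound 4 `Nc1nn(Cc2cn(CC(=O)NC3CCCCC3)nn2)c2nc(-c3ccccc3)cc(C(F)(F)F)c12` keeps everything in compound 3 except for one exchange, with cyclohexyl in place of 4-methylphenyl on an amide-type nitrogen. The aromatic ring of carbon gives way to a non-aromatic one. Within the data shown here, no measured pair makes this exact exchange, so the closest evidence is the three steps above, and none of them goes beyond the scatter. That evidence is thin, as it rests on three compounds, and none of them carries a non-aromatic ring in this group.

Even so, no step beyond the scatter is expected here, and the estimate is a 1.1-fold higher number from compound 3 to compound 4 (0.06 log units; within the scatter). The estimated value for compound 4 is 75 ug/mL, with an expected range from 40 ug/mL to 125 ug/mL.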

Compound 4, half-maximal inhibitory concentration: 89 ug/mL
The estimate for compound 4 lay 1.2-fold (0.07 log units) below the measured number, within the range that was stated.
By their numbers in this assay, from the lowest: compounds 3, 4, 2 and 1 (each within the scatter of the next).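

Among these compounds, this exchange is the first direct look at a non-aromatic ring on the amide-type nitrogen in this assay, and putting cyclohexyl in place of 4-methylphenyl gives a 1.4-fold higher number from compound 3 to compound 4 (0.13 log units; within the scatter). The full (cyclohexylcarbamoyl)methyl group also shows no separation from the groups carried on the aromatic nitrogen by the earlier compounds: against 4-nitrophenyl the result is a 1.1-fold lower number from compound 2 to compound 4 (0.05 log units; within the scatter), and against 3-chloro-4-fluorophenyl it is a 1.1-fold lower number from compound 1 to compound 4 (0.05 log units; within the scatter), so among these four compounds, neither swapping the aromatic ring at the end of the amide for a non-aromatic one nor using an amide-bearing group rather than a directly attached aromatic ring moves the number beyond the scatter. Nothing measured here offers an explanation for this flat picture.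

The compounds shown leave open whether this position would stay as flat with a very different end group, such as an amine or a carboxylic acid in place of cyclohexyl, or with a longer chain in place of the methyl link before the amide. Going by these compounds, the shared core is the same in all four compounds, so what it contributes to these numbers also remains unknown.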